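Replacing hydroxy with azido on compound 2

The source may report more compounds than this note shows. Statements on the series, on what has been measured and on what is new or still open speak of the compounds shown alone.

Measured in a functional assay on HCT-116 cells (Homo sapiens) for antiproliferative activity, read by MTT assay, with a stated time of 48 h; on this read-out higher numbers stand for weaker inhibition and lower numbers for stronger inhibition:
compound 1 `CCCCCCCC[C@H](CCO)n1cnc2c(Cl)ncnc21`: 1120 nM
compound 2 `CCCCCCCCC[C@H](CCO)n1cnc2c(Cl)ncnc21`: 450 nM

Among the compounds with values here, of the two measured compounds, compound 2 has the lower number at 450 nM, and its only neighbour, compound 1 , stands higher at 1120 nM. Within the data shown here, the one measured step is a 2.5-fold lower number from compound 1 to compound 2 (0.40 log units; beyond the scatter). It is modest and beyond the scatter, and it concerns methyl in place of hydrogen on a saturated chain carbon, nine bonds along the chain from an aromatic nitrogen.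

Compound 3 `CCCCCCCCC[C@H](CCN=[N+]=[N-])n1cnc2c(Cl)ncnc21` differs from compound 2 elsewhere, with azido in place of hydroxy on a saturated chain carbon, three bonds along the chain from an aromatic nitrogen. Among the measured compounds shown here, the measured step involves another group at another place, so it bears on this change only weakly, and no measured pair covers the loss of hydroxy. The expectation in this assay therefore starts from compound 2 at 450 nM and foresees no step beyond the scatter, though with wide uncertainty in either direction. The estimated change is a 1.3-fold higher number from compound 2 to compound 3 (0.12 log units; within the scatter). For compound 3 the expected value is 600 nM, with an estimated range of 180 nM to 2000 nM.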

Compound 3, half-maximal inhibitory concentration: 1190 nM
Estimate against measurement, compound 3: 2.0-fold (0.30 log units) below; low and high end bracket the measured number.
By their numbers in this assay, from the lowest: compound 2; then compounds 1 and 3 (each within the scatter of the next).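

In this assay, azido in place of hydroxy gives a 2.6-fold higher number from compound 2 to compound 3 (0.42 log units; beyond the scatter), a modest step. The earlier compounds shown here showed a response only to the length of the alkyl chain, with a 2.5-fold lower number from compound 1 to compound 2 (0.40 log units; beyond the scatter), whereas this result shows that the number also responds to a change on a saturated chain carbon, three bonds along the chain from an aromatic nitrogen, so the hydroxy of compound 2 cannot be exchanged for azido without a step beyond the scatter. The change swaps a hydrogen-bond donor and a single oxygen for a group with no donor and three nitrogens, but nothing presented here shows which of these differences matters, and no measurement bears on the reason for the step.

The compounds shown leave open whether the higher number of compound 3 is specific to azido or would also appear with another group at this place, such as an amine, a methoxy group or a carboxylic acid. From the compounds shown here alone, it is also open whether the same exchange would give a step of similar size on the shorter alkyl chain of compound 1.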